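The source may hold more compounds than are shown below. What is called first, only, known or untested is meant among the compounds shown, and "the series" means these compounds.

Measured so far, in a functional assay on Bel-7402 cells (Homo sapiens) for cytotoxicity, read by MTT assay, with a stated time of 24 h; on this read-out lower numbers stand for stronger inhibition and higher numbers for weaker inhibition:
- compound 1 `CC[C@H](C)[C@@H](NC(=O)Cn1cc(C2=C(c3c[nH]c4ccccc34)C(=O)N(C)C2=O)c2ccccc21)C(=O)OC` — > 100000 nM
- compound 2 `COC(=O)CCNC(=O)Cn1cc(C2=C(c3c[nH]c4ccccc34)C(=O)N(C)C2=O)c2ccccc21` — 28400 nM

The value given for compound 1 is a limit of this assay, not a number (the limit of > 100000 nM in this assay, at which 1 of the 2 values shown sits). Compound 2 therefore stands on the only number shown. Compound 3 `COC(=O)[C@@H](CO)NC(=O)Cn1cc(C2=C(c3c[nH]c4ccccc34)C(=O)N(C)C2=O)c2ccccc21` differs from compound 2 by 2-hydroxy-1-(methoxycarbonyl)ethyl in place of 2-(methoxycarbonyl)ethyl on an amide-type nitrogen. Within the data shown here, one measured step bears on this: an at least 3.5-fold lower number from compound 1 to compound 2 (0.54 log units; beyond the scatter), where a 1-(methoxycarbonyl)-substituted, branched chain on the amide-type nitrogen sat at the limit and the unbranched 2-(methoxycarbonyl)ethyl chain gave a number. Compound 3 returns to a chain carrying the methoxycarbonyl group on the carbon next to the amide-type nitrogen, as in compound 1, though with 2-hydroxy in place of 2-methylbutyl. A step back toward a higher number, of modest size, is therefore expected, as a 1.9-fold higher number from compound 2 to compound 3 (0.29 log units; within the scatter). Compound 3 is estimated at 55000 nM, within 15000 nM to 200000 nM.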

Compound 3, half-maximal inhibitory concentration: 67200 nM
Estimate against measurement, compound 3: 1.2-fold (0.09 log units) below, and the stated range covers the measured number.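

In this assay, 2-hydroxy-1-(methoxycarbonyl)ethyl in place of 2-(methoxycarbonyl)ethyl on the amide-type nitrogen gives a 2.4-fold higher number from compound 2 to compound 3 (0.37 log units; beyond the scatter), so this substituent affects the read-out and compound 2, with its steps from both other compounds beyond the scatter, keeps the lowest number of the three. The value of compound 1 is a limit of the assay, not a number: the limit of > 100000 nM in this assay, at which 1 of the 3 values shown sits. Hydroxymethyl in place of sec-butyl gives an at least 1.4-fold lower number from compound 1 to compound 3 (0.17 log units; that floor lies within the scatter), so compound 3 has a measured number, but the floor of this step does not separate it from compound 1 beyond the scatter.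

Compound 3 adds the hydroxy group and moves the methoxycarbonyl group in one change, and the compounds shown do not separate these two effects. Also open, from the compounds shown here alone, is how a carboxylic acid in place of the methyl ester, or a longer chain or an amine on the amide-type nitrogen, would read.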